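Replacing the 4-isopropylphenyl group of compound 3

This account rests on a few compounds, and the source may have more. Where it says the series, first, only, none or still open, it means among the compounds named here.

Of the compounds shown here, three sharing one core have been measured in an ADME assay on HEK293 cells (Homo sapiens) for cytotoxicity, read by MTT assay, with a stated time of 48 h; a lower number here means a stronger inhibitor, a higher number a weaker inhibitor. Compound 1 `Cc1ccc(/C=C2/S/C(=N/c3ccccc3)N(Cc3ccncc3)C2=O)cc1` gives 49500 nM, compound 2 `O=C1/C(=C\c2ccc(O)cc2)S/C(=N/c2ccccc2)N1Cc1ccncc1` gives 142000 nM, and compound 3 `CC(C)c1ccc(/C=C2/S/C(=N/c3ccccc3)N(Cc3ccncc3)C2=O)cc1` gives 137000 nM. The high end of these numbers is shared: the data show a 1.0-fold lower number from compound 2 to compound 3 (0.02 log units; within the scatter), and also a 2.8-fold higher number from compound 1 to compound 3 (0.44 log units; beyond the scatter).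

The next compound, compound 4 `COc1cc(/C=C2/S/C(=N/c3ccccc3)N(Cc3ccncc3)C2=O)ccc1O`, carries one structural change: 4-hydroxy-3-methoxyphenyl in place of 4-isopropylphenyl on a double-bonded chain carbon bound to a double-bonded ring carbon. In words, this is 4-hydroxy-3-methoxyphenyl in place of 4-isopropylphenyl on a double-bonded chain carbon bound to a double-bonded ring carbon.

The closest guide is compound 2, which also has a hydroxy group on that aromatic ring. Exchanging hydroxy and isopropyl gave a 1.0-fold lower number from compound 2 to compound 3 (0.02 log units; within the scatter), so that swap alone moved the number by no more than the scatter. Within the data shown here, the only modest steps start from the methyl group of compound 1, namely a 2.9-fold higher number from compound 1 to compound 2 (0.46 log units; beyond the scatter) and a 2.8-fold higher number from compound 1 to compound 3 (0.44 log units; beyond the scatter), and compound 4 has no such group. Among the measured compounds shown here, no measured compound here shows what the added methoxy group does, so the range must stay wide.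

The expected change is small and within the scatter, an estimated 1.2-fold lower number from compound 3 to compound 4 (0.10 log units; within the scatter). For compound 4 the estimated value is 110000 nM, with an expected range from 45000 nM to 250000 nM.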

Compound 4, half-maximal inhibitory concentration: 67400 nM
Beside the measured number, compound 4's estimate is 1.6-fold (0.21 log units) above it; low and high end bracket the measured number.
By their numbers in this assay, from the lowest: compounds 1 and 4 (each within the scatter of the next); then compounds 3 and 2 (each within the scatter of the next).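

Among these compounds, compound 2 and compound 4 differ only by methoxy in place of hydrogen on an aromatic carbon, so a 2.1-fold lower number from compound 2 to compound 4 (0.32 log units; beyond the scatter) gives the first direct reading of what this added group does in this assay, and that step is modest. Exchanging the whole ring gives a modest step of similar size, a 2.0-fold lower number from compound 3 to compound 4 (0.31 log units; beyond the scatter), which shows that a ring carrying a hydroxy group does not necessarily stay at the high end of the numbers shared by compound 2 and compound 3. Compared with the 4-methylphenyl ring, the new ring gives a 1.4-fold higher number from compound 1 to compound 4 (0.13 log units; within the scatter), which lies within the scatter, so these two groups cannot be told apart at this position even though one carries hydrogen-bond donors and acceptors and the other does not.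

Nothing measured here explains why the added methoxy group shifts the number. The compounds shown also leave open whether the methoxy step would hold on a ring without the hydroxy group, and how an amine, a carboxylic acid or a longer chain on this ring would read.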